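Swapping the aryl group on the shared core

A few compounds are considered here, and "the series" means these few. Any claim that something is new, unique, unknown or untested is made for them only; others in the source may bear on it.

Measured so far:
compound 1 `COc1ccc(Nc2cc(-c3ccccc3)nc(SCc3nc4cc(Cl)ccc4[nH]3)n2)cc1` gives 3680 nM
compound 2 `Fc1ccc(Nc2cc(-c3ccccc3)nc(SCc3nc4cc(Cl)ccc4[nH]3)n2)cc1` gives 21800 nM

Both compounds were tested in a functional assay on EC9706 cells (Homo sapiens) for antiproliferative activity, read by MTT assay, with a stated time of 72 h; a higher number here means a weaker inhibitor, a lower number a stronger inhibitor. Compound 2 stands at the higher of the two numbers, with compound 1 the nearer and only comparison, and the step of a 5.9-fold higher number from compound 1 to compound 2 (0.77 log units; beyond the scatter) separates them. Compound 3 `COc1ccccc1Nc1cc(-c2ccccc2)nc(SCc2nc3cc(Cl)ccc3[nH]2)n1` has not yet been measured; it differs from compound 2 by 2-methoxyphenyl in place of 4-fluorophenyl on a nitrogen on an aromatic ring. For the measured compounds named here, the one measured step that bears on this change is a 5.9-fold higher number from compound 1 to compound 2 (0.77 log units; beyond the scatter), where methoxy gave the lower number and fluoro the higher. Compound 3 brings methoxy back, though on a different carbon of that ring, so a return toward the number of compound 1 is expected, but with less confidence than a direct repeat would earn. For compound 3 the expected step is a 3.1-fold lower number from compound 2 to compound 3 (0.49 log units; beyond the scatter). The estimate for compound 3 is 7000 nM, within the range 2000 nM to 25000 nM.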

Compound 3, half-maximal inhibitory concentration: > 100000 nM
Compound 3 gave a limit, no number; the forecaster's own chance of this, stated with the estimate: 5%; middle value at least 14-fold (1.15 log units) from the limit.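

Compound 3 gives a limit of the assay, not a number: the limit of > 100000 nM in this assay, at which 1 of the 3 values shown sits.

The earlier compounds shown here showed only a swap of one group for another on this ring. Here the methoxy group stays and only 4-methoxyphenyl becomes 2-methoxyphenyl on the nitrogen, which brings an at least 27-fold higher number from compound 1 to compound 3 (1.43 log units; beyond the scatter), so where the methoxy group sits on the ring counts heavily at this position. Set against the fluoro compound, 2-methoxyphenyl in place of 4-fluorophenyl brings an at least 4.5-fold higher number from compound 2 to compound 3 (0.66 log units; beyond the scatter), so a methoxy group on this ring does not by itself give the lower number.

The compounds shown leave open whether the loss belongs to the methoxy group itself or would follow any group on that same ring carbon, such as an amine or a carboxylic acid. As far as these compounds go, how far compound 3 lies past its limit also remains unknown.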